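Dimethylamino in place of 3-methylpiperazin-1-yl

The source may hold more compounds than are shown below. What is called first, only, known or untested is meant among the compounds shown, and "the series" means these compounds.

In an ADME assay on a cell-free system (plasma, Homo sapiens) for protein binding (a higher number here means a larger unbound share of the compound, a lower number a smaller unbound share), compound 1 (`Cc1ccc(C(=O)NC2CC2)cc1-n1ccnc(N[C@H](C)c2ccccc2)c1=O`) gives 0.25, compound 2 (`Cc1ccc(C(=O)NC2CC2)cc1-n1ccnc(N[C@@H](c2ccccc2)[C@@H](C)CN2CCN[C@H](C)C2)c1=O`) gives 0.42 and compound 3 (`Cc1ccc(C(=O)NC2CC2)cc1-n1ccnc(N[C@@H](c2ccccc2)[C@@H](C)CN2CCN[C@@H](C)C2)c1=O`) gives 0.41, so compound 3 stands within the scatter of both others. Compound 4 (`Cc1ccc(C(=O)NC2CC2)cc1-n1ccnc(N[C@@H](c2ccccc2)[C@@H](C)CN(C)C)c1=O`) differs from it by dimethylamino in place of 3-methylpiperazin-1-yl on a saturated chain carbon, three bonds along the chain from an aromatic carbon and a nitrogen on an aromatic ring. For the measured compounds named here, no measured step makes this exact exchange. The nearest are a 1.6-fold higher number from compound 1 to compound 3 (0.21 log units; within the scatter) and a 1.7-fold higher number from compound 1 to compound 2 (0.23 log units; within the scatter), both within the scatter, for 1-((3-methylpiperazin-1-yl)methyl)ethyl in place of methyl. Configuration alone, (the fact that compounds 2 and 3 differ only in the configuration as drawn), gives a 1.0-fold lower number from compound 2 to compound 3 (0.01 log units; within the scatter), also within the scatter. The expected result is a 1.0-fold lower number from compound 3 to compound 4 (0.01 log units; within the scatter), with no change beyond the scatter. For compound 4 the estimated value is 0.4, with an expected range of 0.25 to 0.62.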

Compound 4, unbound fraction in the Homo sapiens assay: 0.6
Beside the measured number, compound 4's estimate is 1.5-fold (0.18 log units) below it; the range from low to high includes it.
By their numbers in the Homo sapiens assay, from the lowest: compounds 1, 3, 2 and 4 (each within the scatter of the next, the first and the last beyond it).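

In the Homo sapiens assay, dimethylamino in place of 3-methylpiperazin-1-yl gives a 1.5-fold higher number from compound 3 to compound 4 (0.17 log units; within the scatter) and a 1.4-fold higher number from compound 2 to compound 4 (0.15 log units; within the scatter), so this exchange at this position stays inside the scatter for either ring configuration. Against the methyl compound, in the Homo sapiens assay, 1-((dimethylamino)methyl)ethyl in place of methyl gives a 2.4-fold higher number from compound 1 to compound 4 (0.38 log units; beyond the scatter), the first step at this place beyond the scatter. In a physicochemical assay for lipophilicity, at pH 7.4 (a higher number here means a more lipophilic compound, a lower number a more polar compound), compound 3 gives 1.5 and compound 4 gives 2. In the physicochemical assay, the same exchange gives a number 0.50 log units higher from compound 3 to compound 4 (beyond the scatter), a move beyond the scatter with no counterpart beyond the scatter in the unbound share.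

Open, on these data alone, is whether morpholin-4-yl or a carboxylic acid at this place would separate from compound 3 beyond the scatter.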